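Series notes: pyridin-3-yl to methyl on the shared core

The source may report more compounds than this note shows. Statements on the series, on what has been measured and on what is new or still open speak of the compounds shown alone.

Within the data shown here, compound 2 `c1cncc(-c2nnc(-c3c[nH]c4ccccc34)o2)c1` gives the only number: in a functional assay on LNCaP cells (Homo sapiens) for cytotoxicity, read by MTT assay (on this read-out lower numbers stand for stronger inhibition and higher numbers for weaker inhibition), compound 2 reaches 69400 nM. Compound 1 `c1ccc(Cc2nnc(-c3c[nH]c4ccccc34)o2)cc1` sits at a limit of this assay, > 1000000 nM. Compound 3 `COc1ccc(-c2nnc(-c3c[nH]c4ccccc34)o2)c(OC)c1OC` likewise sits at a limit, > 1000000 nM. Among the measured compounds shown here, the one measured step is an at least 14-fold lower number from compound 1 to compound 2 (1.15 log units; beyond the scatter), and the relevant evidence is the limit of > 1000000 nM in this assay, at which 2 of the 3 values shown sit.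

Compound 4 `Cc1nnc(-c2c[nH]c3ccccc23)o1` differs from compound 2 by methyl in place of pyridin-3-yl on an aromatic carbon. For the measured compounds named here, that step removes the very group whose arrival marked the only step beyond the scatter, so a large weakening from compound 2 to compound 4 in this assay is expected, with a fair chance of landing at the limit. Compound 4 is estimated at 400000 nM, between 70000 nM and 1000000 nM, which is the expected step of a 5.8-fold higher number from compound 2 to compound 4 (0.76 log units; beyond the scatter).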

Compound 4, half-maximal inhibitory concentration: > 1000000 nM
Compound 4: only a limit was reported (the forecaster's own chance of this, stated with the estimate: 50%); at least 2.5-fold (0.39 log units) between middle value and limit.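

In this assay, methyl in place of pyridin-3-yl gives an at least 14-fold higher number from compound 2 to compound 4 (1.15 log units; beyond the scatter), so the measurable activity is lost with this one-carbon group as well as with benzyl. Compound 4 sits at a limit, > 1000000 nM. The step between the two limit compounds, compound 1 and compound 4, cannot be read, and pyridin-3-yl remains the only group here with a number: the limit of > 1000000 nM in this assay, at which 3 of the 4 values shown sit.

From the compounds shown here alone, whether the ring nitrogen of pyridin-3-yl is what counts stays open. Unsubstituted phenyl, pyridin-4-yl or an aminomethyl group at this carbon would help to settle that.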